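This account rests on a few compounds, and the source may have more. Where it says the series, first, only, none or still open, it means among the compounds named here.

Measured compounds in a physicochemical assay for lipophilicity, read by HPLC, measured as octanol-water partition; a higher number here means a more lipophilic compound, a lower number a more polar compound:
compound 1 `CC(=O)OC[C@H]1CN(c2ccc(-n3cc(-c4ccccn4)cn3)c(F)c2)C(=O)O1`, 2.09
compound 2 `O=C(OC[C@H]1CN(c2ccc(-n3cc(-c4ccccn4)cn3)c(F)c2)C(=O)O1)c1ccccc1`, 4.21
compound 3 `O=C1O[C@@H](Cn2ccnc2)CN1c1ccc(-n2cc(-c3ccccn3)cn2)c(F)c1`, 1.73

Compound 3 stands lowest of the three in this assay; its nearest neighbour is compound 1, a number 0.36 log units lower from compound 1 to compound 3 (beyond the scatter), and the furthest is compound 2, a number 2.48 log units lower from compound 2 to compound 3 (beyond the scatter).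

Compound 4 `CNC(=O)[C@H]1CN(c2ccc(-n3cc(-c4ccccn4)cn3)c(F)c2)C(=O)O1` is unmeasured and differs from compound 3 in one place: methylcarbamoyl in place of (1H-imidazol-1-yl)methyl on a saturated ring carbon.

Among the measured compounds shown here, both measured steps into compound 3 bear on this change only through the group that leaves; no measured step shows methylcarbamoyl entering. They place the (1H-imidazol-1-yl)methyl group below acetoxy and far below benzoyloxy. Against that background compound 4 is expected to move further down, by a modest step beyond the scatter, a number 0.48 log units lower from compound 3 to compound 4 (beyond the scatter). The estimate for compound 4 is 1.25, within 0.7 to 1.8.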

Compound 4, partition coefficient: 1.39
Compound 4: the middle estimate sits 0.14 log units below what was measured; measured number inside the range.
By their numbers in this assay, from the lowest: compound 4; then compound 3; then compound 1; then compound 2.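

At the saturated ring carbon next to the ring oxygen, methylcarbamoyl in place of (1H-imidazol-1-yl)methyl lowers the number in this assay once more, a number 0.34 log units lower from compound 3 to compound 4 (beyond the scatter). In place of acetoxymethyl the same group gives a number 0.70 log units lower from compound 1 to compound 4 (beyond the scatter), and in place of (benzoyloxy)methyl it gives a number 2.82 log units lower from compound 2 to compound 4 (beyond the scatter). Compound 4 therefore marks the low end of the range at this position among the four compounds.

Nothing at hand gives a reason for these steps. On these data alone, how a primary amine, a carboxylic acid or ethylcarbamoyl on this carbon would read remains open.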